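Swapping 4-methylphenyl for 3,4-difluorophenyl on a sulfonamide nitrogen

This account rests on a few compounds, and the source may have more. Where it says the series, first, only, none or still open, it means among the compounds named here.

Going by the values given here, compound 2 `Cc1ccc(NS(=O)(=O)c2ccc(N3CCNC3=O)cc2)cc1` gives 610 nM in a functional assay on MCF7 cells (Homo sapiens) for antiproliferative activity, read by sulforhodamine B assay, with a stated time of 48 h (a higher number here means a weaker inhibitor, a lower number a stronger inhibitor), and holds the only true number so far. Compound 1 `O=C1NCCN1c1ccc(S(=O)(=O)Nc2ccc(C3CCCCC3)cc2)cc1` reads > 1000 nM as a limit of the assay, not a number. Compound 3 `CCCCCCCc1ccc(NS(=O)(=O)c2ccc(N3CCNC3=O)cc2)cc1` reads > 1000 nM as a limit too. Compound 4 `O=C1NCCN1c1ccc(S(=O)(=O)Nc2ccc(F)c(F)c2)cc1` differs from compound 2 by 3,4-difluorophenyl in place of 4-methylphenyl on a sulfonamide nitrogen in that 3,4-difluorophenyl replaces 4-methylphenyl on a sulfonamide nitrogen. Two measured steps change this same group: an at least 1.6-fold lower number from compound 1 to compound 2 (0.21 log units; that floor lies within the scatter) and an at least 1.6-fold higher number from compound 2 to compound 3 (0.21 log units; that floor lies within the scatter) are floors within the scatter, and neither brings in fluorine. Compound 4 is therefore expected to show no step beyond the scatter in this assay relative to compound 2. The estimated change is a 1.0-fold lower number from compound 2 to compound 4 (0.01 log units; within the scatter) in size. Compound 4 is estimated at 600 nM with 220 nM to 1600 nM as its expected range.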

Compound 4, half-maximal inhibitory concentration: 620 nM
Compound 4: the middle estimate sits 1.0-fold (0.01 log units) below what was measured, and the stated range covers the measured number.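

Swapping the aromatic group on the sulfonamide nitrogen gives a 1.0-fold higher number from compound 2 to compound 4 (0.01 log units; within the scatter) in this assay. Going by these compounds alone, this is the first step at this position read between two true numbers, and it shows that 3,4-difluorophenyl and 4-methylphenyl cannot be told apart here, even though one carries fluorine and the other a methyl. Compound 1 and compound 3 remain limits of the assay, so they cannot show how far larger groups here shift the number: the limit of > 1000 nM in this assay, at which 2 of the 4 values shown sit.

Still open, going by these compounds, is whether a single fluorine would read the same as two. Also open, on these data alone, is whether a phenyl ring carrying an amine or a carboxylic acid would stay at this level.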